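Swapping an aryloxy arm for an oxazole at the anilide ring

This account rests on a few compounds, and the source may have more. Where it says the series, first, only, none or still open, it means among the compounds named here.

The series shares one core, an amide-linked piperidine carrying an aroyl group, and varies the substituent on the anilide ring. Compound 1 `COC(=O)c1cc(-c2cccc(NC(=O)C3CCCN(C(=O)c4cc(C(F)(F)F)cc(C(F)(F)F)c4)C3)c2)co1` was tested in an ADME assay on PC-3 cells (Homo sapiens) for cytotoxicity, read by WST assay, tested at 100 uM (on this read-out higher numbers stand for more inhibition at the one concentration tested (going by the name of the read-out) and lower numbers for less inhibition), and gave 0%. Compound 2 `O=C(Nc1cccc(Oc2nccc(C(F)(F)F)c2Cl)c1)C1CCCN(C(=O)c2cc(C(F)(F)F)cc(C(F)(F)F)c2)C1`, in which the arm on the anilide ring is changed, gave in this assay a reading of 0%. Among the compounds with values here, the only measured step therefore runs no change at the digits printed from compound 1 to compound 2 (within the scatter), which places compound 2 level with compound 1 at the floor of the read-out; neither compound shows any effect at the single concentration tested.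

Compound 3 `O=C(Nc1cccc(-c2cnco2)c1)C1CCCN(C(=O)c2cc(C(F)(F)F)cc(C(F)(F)F)c2)C1` is the next member. It differs from compound 2 by 1,3-oxazol-5-yl in place of (3-chloro-4-(trifluoromethyl)pyridin-2-yl)oxy on an aromatic carbon. Within the data shown here, no measured step involves an oxazole, but the one step available, no change at the digits printed from compound 1 to compound 2 (within the scatter), shows that a large exchange at the same position of the anilide ring left the read-out unchanged. On that basis the step of no change at the digits printed from compound 2 to compound 3 (within the scatter) is expected to stay within the scatter. Compound 3 is estimated to give 0% in this assay, with a range from -10% to 10%.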

Compound 3, a percentage reported as inhibition, at one concentration (the size of the read-out at that concentration, not a potency): 9%
The estimate for compound 3 lay 9 percentage points below the measured number, within the range that was stated.
By their numbers in this assay, from the lowest: compounds 1, 2 and 3 (each within the scatter of the next).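

In this assay, putting 1,3-oxazol-5-yl in place of the (3-chloro-4-(trifluoromethyl)pyridin-2-yl)oxy arm gives a number 9 percentage points higher from compound 2 to compound 3 (within the scatter) and putting it in place of the 5-(methoxycarbonyl)furan-3-yl arm gives a number 9 percentage points higher from compound 1 to compound 3 (within the scatter). The earlier pair had only shown one exchange at this aromatic carbon, whereas these steps add a single five-membered aromatic ring of 5 heavy atoms, against the 12 heavy atoms of the aryloxy arm it replaces, and the reading stays within the scatter. The three compounds therefore cannot be told apart in this assay despite that difference in size at the position, and nothing available bears on the reason for these readings.

The compounds shown leave open whether an amine, a carboxylic acid or a longer alkyl chain on this same aromatic carbon would move the reading beyond the scatter. They also leave open whether a simple unsubstituted phenyl ring, or a hydrogen in place of any arm, would read differently from the oxazole of compound 3.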